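This account rests on a few compounds, and the source may have more. Where it says the series, first, only, none or still open, it means among the compounds named here.

Compound 3 `COc1n[nH]c2ncc(-c3cn(-c4c(F)ccc(NS(=O)(=O)c5ccccc5)c4F)nn3)cc12` gives 3.8 nM in an assay on Sf9 cells for inhibition of mitogen-activated protein kinase kinase kinase 20 (Homo sapiens), read by ADP-Glo, with a stated time of 30 min; on this read-out lower numbers stand for stronger inhibition and higher numbers for weaker inhibition. Among the three measured compounds it holds the second highest number: its nearest neighbour, compound 2 `COc1n[nH]c2ncc(-c3cn(-c4c(F)ccc(NS(=O)(=O)c5cccc(Cl)c5)c4F)nn3)cc12` with 1.9 nM, sits a step below it, and the furthest, compound 1 `COc1n[nH]c2ncc(C#Cc3c(F)ccc(NS(=O)(=O)c4cccc(Cl)c4)c3F)cc12` with 14.7 nM, lies a step above it. Compound 4 `COc1n[nH]c2ncc(-c3cn(-c4c(F)ccc(NS(=O)(=O)c5cccc(C#N)c5)c4F)nn3)cc12` differs from compound 3 in one place: cyano in place of hydrogen on an aromatic carbon. Going by the values given here, the only measured step at that place is a 2.0-fold higher number from compound 2 to compound 3 (0.30 log units; within the scatter), which removed a chloro at the same aromatic carbon without moving the number beyond the scatter. On that basis a small change at most is expected from compound 3 to compound 4, a 1.4-fold lower number from compound 3 to compound 4 (0.13 log units; within the scatter), in no clear direction. Compound 4 is therefore estimated at 2.8 nM, with a range from 1 nM to 8 nM.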

Compound 4, half-maximal inhibitory concentration: 3.3 nM
Beside the measured number, compound 4's estimate is 1.2-fold (0.07 log units) below it; the range from low to high includes it.
By their numbers in this assay, from the lowest: compounds 2, 4 and 3 (each within the scatter of the next); then compound 1.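

In this assay, a third group at this aromatic carbon gives a 1.2-fold lower number from compound 3 to compound 4 (0.06 log units; within the scatter), and exchanging chloro for cyano gives a 1.7-fold higher number from compound 2 to compound 4 (0.24 log units; within the scatter). Hydrogen, chloro and cyano are thus not separated here, so a group with a triple bond and a hydrogen-bond acceptor also stays within the scatter at this carbon. Nothing available explains this result. Going by these compounds, whether an amine or a carboxylic acid at this carbon would also stay within the scatter remains open. So does whether cyano would behave the same way in the core of compound 1.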